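From ethyl to isopropyl in a small series

This account rests on a few compounds, and the source may have more. Where it says the series, first, only, none or still open, it means among the compounds named here.

Compound 1 `Cc1nc(Cc2c[nH]cn2)c(C)s1`: > 30 mg/kg (a limit)
Compound 2 `CCc1nc(Cc2c[nH]cn2)c(CC)s1`: 1.8 mg/kg

The compounds were tested in a functional assay on the whole organism (Abdomen) with Mus musculus as the target; on this read-out lower numbers stand for an effect already at smaller amounts and higher numbers for an effect only at larger amounts of compound. Compound 1 is reported at > 30 mg/kg, which is a limit of the assay and not a number. For the measured compounds named here, compound 2 gives 1.8 mg/kg, the only true number so far, so it has no measured step to be compared with.

Compound 3 `CCc1sc(C(C)C)nc1Cc1c[nH]cn1` differs from compound 2 by one change, ethyl to isopropyl: methyl in place of hydrogen on a saturated chain carbon bound to an aromatic carbon and a saturated chain carbon. This puts methyl in place of hydrogen on a saturated chain carbon bound to an aromatic carbon and a saturated chain carbon.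

Going by the values given here, with no measured step as a guide, the expectation rests on compound 2 at 1.8 mg/kg and on how small the change is. No shift beyond the usual scatter is expected in this assay, and no firm direction. The expected change is a 1.2-fold lower number from compound 2 to compound 3 (0.08 log units; within the scatter). For compound 3 the estimated value is 1.5 mg/kg, with an expected range from 0.5 mg/kg to 6 mg/kg.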

Compound 3, dose for half-maximal effect: 7.5 mg/kg
Compound 3: middle estimate off by 5.0-fold (0.70 log units), on the low side; the whole stated range lies below it.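

In this assay, this position does not take the change freely: one added methyl, turning ethyl into isopropyl, gives a 4.2-fold higher number from compound 2 to compound 3 (0.62 log units; beyond the scatter). For the compounds shown here, this is the first measured step, and it shows that a methyl in place of hydrogen on a saturated chain carbon bound to an aromatic carbon and a saturated chain carbon means that a larger dose is needed for the same effect. No information shown here bears on the reason for this step.

On these data alone, whether a cyclopropyl ring, a tert-butyl group or an amine at this place would move the number further remains open. Going by these compounds alone, compound 1 is reported at > 30 mg/kg, which is a limit and not a number, and it differs from the other compounds in more than one place, so no step to it can be read.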